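This account rests on a few compounds, and the source may have more. Where it says the series, first, only, none or still open, it means among the compounds named here.

Among the measured compounds shown here, compound 2 `CC(C)(C)c1ccc(CN2C(=O)S/C(=C\c3cccc(N)c3)C2=O)cc1` gives 188000 nM in a functional assay on FM3A cells (Mus musculus) for cytotoxicity, read by cell counting, with a stated time of 2 days (a higher number here means a weaker inhibitor, a lower number a stronger inhibitor), the higher of the two numbers known; compound 1 `CC(C)(C)c1ccc(CN2C(=O)S/C(=C\c3ccc(N)cc3)C2=O)cc1` gives 80000 nM, and the two are separated by a 2.4-fold higher number from compound 1 to compound 2 (0.37 log units; beyond the scatter). Compound 3 `Nc1cccc(/C=C2\SC(=O)N(Cc3ccc(Cl)cc3)C2=O)c1` differs from compound 2 by chloro in place of tert-butyl on an aromatic carbon, a chloro in place of tert-butyl on an aromatic carbon, para to a large group. For the measured compounds named here, the only measured step concerns the position of the amino group, so no measured step bears on this change. The expected step is therefore no change at the digits printed from compound 2 to compound 3 (within the scatter), nothing beyond the usual scatter. Compound 3 is estimated at 188000 nM in this assay, between 60000 nM and 550000 nM.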

Compound 3, half-maximal inhibitory concentration: 246000 nM
Beside the measured number, compound 3's estimate is 1.3-fold (0.12 log units) below it, within the range that was stated.
By their numbers in this assay, from the lowest: compound 1; then compounds 2 and 3 (each within the scatter of the next).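

In this assay, chloro in place of tert-butyl on the aromatic carbon, para to a large group, gives a 1.3-fold higher number from compound 2 to compound 3 (0.12 log units; within the scatter), a step within the scatter. For the pair compared, this position therefore tolerates the exchange of the larger tert-butyl for the single chlorine atom without a change beyond the scatter. Nothing available accounts for this outcome. As far as these compounds go, whether the same holds alongside the 4-aminophenyl of compound 1 remains open. So does the outcome with a methoxy group, a carboxylic acid or a longer chain at this position.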